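A few compounds are considered here, and "the series" means these few. Any claim that something is new, unique, unknown or untested is made for them only; others in the source may bear on it.

Of the compounds shown here, two that share a core have been measured so far in a functional assay on Maver1 cells (Homo sapiens) for inhibition, read by luminescence and CellTiter-Glo, with a stated time of 72 h; a lower number here means a stronger inhibitor, a higher number a weaker inhibitor. Compound 1 `O=C(CCl)Nc1ccc(Cn2nc(-c3ccc(Oc4ccccc4)cc3)cc2CO)cc1` gives 400 nM in this assay, the lower of the two numbers. Compound 2 `C=CC(=O)Nc1cccc(Cn2nc(-c3ccc(Oc4ccccc4)cc3)cc2C(=O)O)c1` gives 37400 nM in this assay, a gap from compound 1 that lies far beyond the usual scatter; since the two differ in several places at once, that gap cannot be tied to any single change. Compound 3 `CCOC(=O)c1cc(-c2ccc(Oc3ccccc3)cc2)nn1Cc1ccc(NC(=O)CCl)cc1` has not yet been measured. It differs from compound 1 in one place only: ethoxycarbonyl in place of hydroxymethyl on an aromatic carbon. Within the data shown here, no measured pair shows this same exchange, so the size of the step has to be judged without a direct precedent. A small weakening is expected, with a wide margin, and the expectation stays anchored to compound 1, which gives 400 nM in this assay. For compound 3 the expected value in this assay is 900 nM, with a range from 150 nM to 6000 nM. This corresponds to an expected step of a 2.3-fold higher number from compound 1 to compound 3 (0.35 log units; beyond the scatter), only slightly beyond the scatter and toward a weaker inhibitor.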

Compound 3, half-maximal inhibitory concentration: 400 nM
Compound 3: middle estimate off by 2.3-fold (0.35 log units), on the high side; the measured number falls inside the stated range.
By their numbers in this assay, from the lowest: compounds 1 and 3 (each within the scatter of the next); then compound 2.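

Among these compounds, exchanging hydroxymethyl for ethoxycarbonyl on an aromatic carbon of the five-membered aromatic ring, next to the ring nitrogen, is the first single change that can be read in this assay, and it gives no change at the digits printed from compound 1 to compound 3 (within the scatter). This pair shows that, in this series, the place can carry the larger ethoxycarbonyl group, which has no hydrogen-bond donor, while the number stays within the scatter of the one for hydroxymethyl, which has one. Nothing available here explains why the two groups read alike.

This single pair leaves open whether other groups at the same place, such as an aminomethyl group, a primary amide or a longer ester chain, would also leave the number where it is. On these data alone, compound 2 carries a carboxylic acid at this place but also differs from compound 1 and compound 3 elsewhere, so the effect of the acid alone remains unknown.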